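A few compounds are considered here, and "the series" means these few. Any claim that something is new, unique, unknown or untested is made for them only; others in the source may bear on it.

Measured compounds in a functional assay on A549 cells (Homo sapiens), read by MTT assay, with a stated time of 72 h; a lower number here means a stronger inhibitor, a higher number a weaker inhibitor:

- compound 1, `Cc1nc(N)c2c(-c3cccs3)cn([C@@H]3O[C@H](CO)[C@@H](O)[C@H]3O)c2n1`: > 20000 nM
- compound 2, `Cc1nc(N)c2c(-c3ccco3)cn([C@@H]3O[C@H](CO)[C@@H](O)[C@H]3O)c2n1`: > 20000 nM
- compound 3, `Nc1nc2c(c(-c3ccco3)cn2[C@@H]2O[C@H](CO)[C@@H](O)[C@H]2O)c(=O)[nH]1`: > 20000 nM

Each of these three values is a limit of the assay, not a number. Compound 1 gives only the limit > 20000 nM in this assay. Compound 2 gives only the limit > 20000 nM. Compound 3 likewise gives only the limit > 20000 nM. Among the measured compounds shown here, the one change made within the measured set is thiophen-2-yl in place of furan-2-yl on an aromatic carbon; its step that the two limits leave unreadable from compound 2 to compound 1 cannot be read because both ends sit at the limit of > 20000 nM in this assay, at which 3 of the 3 values shown sit. The difference between the core of compound 3 and the core of compound 2 is not broken down here.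

Compound 4, `Nc1nc2c(c(-c3cccs3)cn2[C@@H]2O[C@H](CO)[C@@H](O)[C@H]2O)c(=O)[nH]1`, is not yet measured. It differs from compound 3 by thiophen-2-yl in place of furan-2-yl on an aromatic carbon, the same change as from compound 2 to compound 1, with the place described in the same words. For the measured compounds named here, for compound 4 the step that the limit leaves unreadable from compound 3 to compound 4 is expected to be flat, since the only measured instance of this change left both compounds at the limit of > 20000 nM in this assay, at which 3 of the 3 values shown sit. Compound 4 is therefore expected to give about 30000 nM, most likely again as a limit rather than a number.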

Compound 4, half-maximal inhibitory concentration: > 20000 nM
Compound 4 was reported as a limit; the forecaster's own chance of this, stated with the estimate: 85%; the middle value is on the limit's open side.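

No new step can be read from compound 3 to compound 4, because both give only a limit of the assay: the limit of > 20000 nM in this assay, at which 4 of the 4 values shown sit.

The compounds shown leave open whether thiophen-2-yl in place of furan-2-yl on an aromatic carbon, or the difference between the two cores, has any effect on potency in this assay.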